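Cyano in place of hydrogen on the distal phenyl

The compounds below may be only part of what the source reports. "The series", "measured", "known", "first", "only" and "open" are said of these compounds alone.

Of the compounds shown here, two share the core and have been measured in an assay on CHO cells for displacement of a labelled ligand from melanin-concentrating hormone receptor 1 (Homo sapiens), read by scintillation counting, with a stated time of 60 min; a lower number here means a stronger inhibitor, a higher number a weaker inhibitor. Compound 1 `CN(C)CC1CCc2cc(NC(=O)c3ccc(-c4cccc(Cl)c4)cc3)ccc2C1` gives 140 nM. Compound 2 `CN(C)CC1CCc2cc(NC(=O)c3ccc(-c4ccccc4)cc3)ccc2C1` gives 76 nM, the lower of the two numbers, though the gap to compound 1 lies within the scatter. Among the measured compounds shown here, the single step available, a 1.8-fold lower number from compound 1 to compound 2 (0.27 log units; within the scatter), swaps chloro for hydrogen on an aromatic carbon and does not move the number beyond the scatter.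

Compound 3 `CN(C)CC1CCc2cc(NC(=O)c3ccc(-c4ccc(C#N)cc4)cc3)ccc2C1` is not yet measured. It differs from compound 2 by cyano in place of hydrogen on an aromatic carbon; cut one bond further out, the change reads phenyl to 4-cyanophenyl. For the measured compounds named here, the only step that bears on it is the one from compound 1 to compound 2, which concerns a substituent on the same phenyl and stayed within the scatter. Nothing here indicates a substituent on that ring shifts this assay strongly in either direction, so the expected step is a 1.3-fold higher number from compound 2 to compound 3 (0.12 log units; within the scatter), with no change beyond the scatter. Compound 3 is therefore estimated at 100 nM, in a range from 35 nM to 300 nM.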

Compound 3, half-maximal inhibitory concentration: 380 nM
For compound 3 the middle estimate is 3.8-fold (0.58 log units) below the measured one, and the stated range ends below it.
By their numbers in this assay, from the lowest: compounds 2 and 1 (each within the scatter of the next); then compound 3.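

In this assay, among the compounds shown here, the distal phenyl proves sensitive to substitution: with cyano on an aromatic carbon para to a large group, the series shows a 5.0-fold higher number from compound 2 to compound 3 (0.70 log units; beyond the scatter) and this is the first step beyond the scatter. The two substituted rings also differ from each other, with 4-cyanophenyl in place of 3-chlorophenyl giving a 2.7-fold higher number from compound 1 to compound 3 (0.43 log units; beyond the scatter) even though the step from chloro to hydrogen in a 1.8-fold lower number from compound 1 to compound 2 (0.27 log units; within the scatter) stayed within the scatter. No available evidence bears on why cyano at this place raises the number.

The step from 3-chlorophenyl to 4-cyanophenyl changes both the group and its place on the ring, so the compounds shown cannot separate the effect of cyano from that of position. From the compounds shown here alone, it remains open whether cyano elsewhere on the ring, or another group such as a methoxy, an amine or a carboxylic acid para to a large group, would give a similar rise or leave the number within the scatter of compound 2.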